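The source may hold more compounds than are shown below. What is called first, only, known or untested is meant among the compounds shown, and "the series" means these compounds.

Values in a functional assay on KB cells (Homo sapiens) for cytotoxicity, read by spectrophotometry and crystal violet staining; a higher number here means a weaker inhibitor, a lower number a stronger inhibitor:
compound 1 `CC(=O)N/N=C/c1c(Cl)n(C2O[C@H](CO)[C@@H](O)[C@H]2O)c2cc(Cl)c(Cl)cc12`: 9000 nM
compound 2 `N#Cc1c(Cl)n(C2O[C@H](CO)[C@@H](O)[C@H]2O)c2cc(Cl)c(Cl)cc12`: 65000 nM
compound 3 `NC(=O)N/N=C/c1c(Cl)n(C2O[C@H](CO)[C@@H](O)[C@H]2O)c2cc(Cl)c(Cl)cc12`: > 100000 nM

Compound 3 gives > 100000 nM, which is a limit of the assay and not a number. Compound 4 `OC[C@H]1OC(n2c(Cl)c(/C=N/O)c3cc(Cl)c(Cl)cc32)[C@H](O)[C@@H]1O` carries hydroxy in place of ureido on a double-bonded nitrogen. Within the data shown here, no measured step makes this exact change. The closest is an at least 11-fold higher number from compound 1 to compound 3 (1.04 log units; beyond the scatter), which is large and also alters only the end of the group. The step of a 7.2-fold higher number from compound 1 to compound 2 (0.86 log units; beyond the scatter) is modest, and the floor of an at least 1.5-fold higher number from compound 2 to compound 3 (0.18 log units; that floor lies within the scatter) lies within the scatter. Resting on the reach of compound 1 at 9000 nM, a modest move to a lower number is expected in this assay. The expected change is an at least 3.3-fold lower number from compound 3 to compound 4 (0.52 log units; beyond the scatter). Compound 4 is estimated at 30000 nM, within an expected range of 6000 nM to 100000 nM.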

Compound 4, half-maximal inhibitory concentration: 25000 nM
Beside the measured number, compound 4's estimate is 1.2-fold (0.08 log units) above it; the range from low to high includes it.
By their numbers in this assay, from the lowest: compound 1; then compound 4; then compound 2. At a limit, above all of these: compound 3.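

In this assay, hydroxy on the double-bonded nitrogen sits on neither extreme of the end groups: replacing ureido gives an at least 4.0-fold lower number from compound 3 to compound 4 (0.60 log units; beyond the scatter), while replacing acetamido gives a 2.8-fold higher number from compound 1 to compound 4 (0.44 log units; beyond the scatter). Compound 3 stands at a limit and not a number, so the first of these steps is only a floor: the limit of > 100000 nM in this assay, at which 1 of the 4 values shown sits. At the aromatic carbon, the hydroxy-bearing group in place of nitrile gives a 2.6-fold lower number from compound 2 to compound 4 (0.41 log units; beyond the scatter). Left open is how an amine or a longer acyl chain on the double-bonded nitrogen would compare with the acetamido of compound 1.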